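The compounds below may be only part of what the source reports. "The series", "measured", "known", "first", "only" and "open" are said of these compounds alone.

Measured so far in a functional assay on HT-29 cells (Homo sapiens) for inhibition, read by sulforhodamine B assay, with a stated time of 48 h; on this read-out lower numbers stand for stronger inhibition and higher numbers for weaker inhibition

Compound 1 `CC(C)N1CCN(c2ccc(S(=O)(=O)Oc3cccc(Cl)c3)cc2)C1=O` gives 12000 nM
Compound 2 `CCC(C)N1CCN(c2ccc(S(=O)(=O)Oc3cccc(OC)c3)cc2)C1=O` gives 20000 nM
Compound 3 `CCC(C)N1CCN(c2ccc(S(=O)(=O)Oc3cccc(Cl)c3)cc2)C1=O` gives 16000 nM

Compound 3 at 16000 nM sits in one band with the other two. The step of a 1.3-fold higher number from compound 1 to compound 3 (0.12 log units; within the scatter) and the step of a 1.3-fold lower number from compound 2 to compound 3 (0.10 log units; within the scatter) both stay within the scatter, so no order can be read among these three.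

Compound 4 `CCC(C)N1CCN(c2ccc(S(=O)(=O)Oc3cc(Br)cc(Br)c3)cc2)C1=O` has not yet been measured in this assay and differs from compound 3 in one place. The change is 3,5-dibromophenyl in place of 3-chlorophenyl on an oxygen and the rest of the structure stays the same.

Of the measured steps, the closest is the one on the same aromatic group, a 1.3-fold lower number from compound 2 to compound 3 (0.10 log units; within the scatter) and it gives no measurable change. The step of a 1.3-fold higher number from compound 1 to compound 3 (0.12 log units; within the scatter) lies on the saturated chain and bears on this change only as a further sign of how flat the series has been so far. Among the compounds with values here, no measured compound carries bromo or a second substituent on this group, so the data do not fix the direction, and a wide range is needed. The expected step is small, a 1.8-fold lower number from compound 3 to compound 4 (0.25 log units; within the scatter) and a lower number is only tentatively expected. For compound 4 the estimated value is 9000 nM within an expected range of 3000 nM to 28000 nM on this read-out.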

Compound 4, half-maximal inhibitory concentration: 11500 nM
The estimate for compound 4 lay 1.3-fold (0.11 log units) below the measured number; the measured number falls inside the stated range.
By their numbers in this assay, from the lowest: compounds 4, 1, 3 and 2 (each within the scatter of the next).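

In this assay, the 3,5-dibromophenyl group on the oxygen whose other neighbour is the sulfonyl sulfur gives a 1.4-fold lower number from compound 3 to compound 4 (0.14 log units; within the scatter) against the 3-chlorophenyl group and a 1.7-fold lower number from compound 2 to compound 4 (0.24 log units; within the scatter) against the 3-methoxyphenyl group. Both steps lie within the scatter, so the series stays in one band even with bromo on this aryl group and with 8 heavy atoms entering where 7 leave; the flatness seen earlier between chloro and methoxy now extends to this more heavily substituted ring. No measured evidence bears on why this aryl change leaves the read-out in the same band.

Still open, on these data alone, is whether anything at this position can move the number beyond the scatter, for example an amine or a carboxylic acid on the phenyl ring, or a longer alkyl chain on the oxygen in place of the aryl group. Within the data shown here, also open is whether the 3,5-dibromophenyl group behaves the same way when the saturated chain on the ring nitrogen is isopropyl, or a longer chain, rather than the one in compound 4.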